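Swapping a butyl chain for propargyloxy on a dichloro core

The source may report more compounds than this note shows. Statements on the series, on what has been measured and on what is new or still open speak of the compounds shown alone.

Measured compounds:
Compound 1, `CCO/N=C/Nc1cc(Cl)c(CC)c(Cl)c1`: 4.8
Compound 2, `CCCCc1c(Cl)cc(N/C=N/OCC)cc1Cl`: 5.6

Of the compounds shown here, two have so far been measured in a physicochemical assay for lipophilicity, measured as octanol-water partition; on this read-out lower numbers stand for lower lipophilicity and higher numbers for higher lipophilicity. Compound 1 has the structure `CCO/N=C/Nc1cc(Cl)c(CC)c(Cl)c1` and in this assay compound 1 gives 4.8. Compound 2, `CCCCc1c(Cl)cc(N/C=N/OCC)cc1Cl`, gives 5.6 in this assay and so stands highest of the two numbers; its nearest neighbour is compound 1, reached by a number 0.80 log units higher from compound 1 to compound 2 (beyond the scatter).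

The next compound, compound 3, has the structure `C#CCOc1c(Cl)cc(N/C=N/OCC)cc1Cl`. Compared with compound 2 the change is propargyloxy in place of butyl on an aromatic carbon. Among the compounds with values here, the only measured step, a number 0.80 log units higher from compound 1 to compound 2 (beyond the scatter), concerns lengthening a saturated chain and is a different kind of change from the one at hand, so it gives no direct guide; it shows only that the chain on this core matters to the read-out. An oxygen-linked group with an acceptor replacing a hydrocarbon chain of the same heavy-atom count is expected to lower this assay, and the step from compound 2 is therefore estimated at a number 1.20 log units lower from compound 2 to compound 3 (beyond the scatter). Compound 3 is accordingly expected to give about 4.4, within a range from 3.8 to 5.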

Compound 3, partition coefficient: 3.6
Estimate against measurement, compound 3: 0.80 log units above; measured number outside the range, below it.
By their numbers in this assay, from the lowest: compound 3; then compound 1; then compound 2.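

On the aromatic carbon ortho to two chloro groups, this assay shows a number 2.00 log units lower from compound 2 to compound 3 (beyond the scatter) when propargyloxy takes the place of butyl, so two groups with the same count of 4 heavy atoms stand far apart and that count alone does not set the read-out at this position. The same position shows a number 1.20 log units lower from compound 1 to compound 3 (beyond the scatter) when propargyloxy takes the place of ethyl, which places compound 3 lowest of the three and shows that the number falls whichever of the two saturated chains is replaced, something the earlier step along a saturated chain could not show. No measurement at hand accounts for the size of these two steps.

From the compounds shown here alone, whether the drop follows the oxygen link or the triple bond stays open, and a propoxy group on the same aromatic carbon would separate the two. How an amine or a carboxylic acid on this carbon would stand in this assay against these three compounds is open as well.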